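Allyloxy to ethoxy: from compound 2 to compound 4

A few compounds are considered here, and "the series" means these few. Any claim that something is new, unique, unknown or untested is made for them only; others in the source may bear on it.

In a functional assay on KB cells (Homo sapiens) for cytotoxicity (a higher number here means a weaker inhibitor, a lower number a stronger inhibitor), compound 1 (`C/C=C/C(=O)OC1=CC(=O)c2ccccc2C1=O`) stands at 64200 nM and compound 3 (`CC(=O)OC1=CC(=O)c2ccccc2C1=O`) stands at 38800 nM so far. Compound 2 (`C=CCOc1ccc2c(c1)C(=O)C=CC2=O`) gives 10200 nM as the lowest of the three numbers, beyond the scatter from both others.

Compound 4 (`CCOc1ccc2c(c1)C(=O)C=CC2=O`) follows from compound 2 by allyloxy to ethoxy, methyl in place of vinyl on a saturated chain carbon bound to an oxygen on an aromatic ring. Within the data shown here, only one measured step bears on this: a 1.7-fold lower number from compound 1 to compound 3 (0.22 log units; within the scatter) with methyl in place of prop-1-en-1-yl on a carbonyl carbon. That step lies at another place and on another core, so it is only a weak guide, and it stays within the scatter. On that single precedent, no step beyond the scatter is expected in this assay in either direction. The expected step is a 1.2-fold higher number from compound 2 to compound 4 (0.07 log units; within the scatter) and the range is kept wide. Compound 4 is estimated at 12000 nM (expected range 5000 nM to 30000 nM).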

Compound 4, half-maximal inhibitory concentration: 21400 nM
Estimate against measurement, compound 4: 1.8-fold (0.25 log units) below; the measured number falls inside the stated range.
By their numbers in this assay, from the lowest: compound 2; then compounds 4, 3 and 1 (each within the scatter of the next, the first and the last beyond it).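

In this assay the swap of vinyl for methyl on the allyloxy chain gives a 2.1-fold higher number from compound 2 to compound 4 (0.32 log units; beyond the scatter) and so registers as a modest step at this place on the shared core. Among these compounds, the only earlier step with an unsaturated end replaced by methyl, a 1.7-fold lower number from compound 1 to compound 3 (0.22 log units; within the scatter) at a carbonyl carbon on another core, stays within the scatter, so the ether chain is the first place where such a change is readable. Nothing measured here accounts for the step in either its direction or its size.

Going by these compounds, whether the step follows the loss of the double bond or the shorter chain stays open, and a saturated propoxy chain at this place would separate the two. A methoxy group or a longer butoxy chain would show whether the trend continues in either direction.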